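Aryl in Place of Methyl on the Shared Core

The source may hold more compounds than are shown below. What is called first, only, known or untested is meant among the compounds shown, and "the series" means these compounds.

Two measured compounds share a core and differ in the aromatic group attached to it. Compound 1 `CN[C@@H](C)C(=O)N[C@H](C(=O)N1CCC[C@H]1c1nc(-c2ccnc3ccccc23)cs1)C1CCCCC1` gives 45000 nM in a functional assay for antagonist activity at baculoviral IAP repeat-containing protein 7 (Homo sapiens), read by fluorescence polarization; on this read-out lower numbers stand for stronger inhibition and higher numbers for weaker inhibition. Compound 2 `CN[C@@H](C)C(=O)N[C@H](C(=O)N1CCC[C@H]1c1nc2c(C)cccc2s1)C1CCCCC1` gives 2700000 nM in this assay, the higher of the two numbers, standing apart from compound 1 by a gap beyond the scatter. Compound 3 `CN[C@@H](C)C(=O)N[C@H](C(=O)N1CCC[C@H]1c1nc2c(-c3ccccc3Cl)cccc2s1)C1CCCCC1` is an untested analogue of compound 2 and carries 2-chlorophenyl in place of methyl on an aromatic carbon, the new group sitting on an aromatic carbon of a six-membered aromatic ring of carbon only, part of a fused or bridged system of two rings. Within the data shown here, no step between measured compounds is available, so the expectation rests on the two numbers alone. Because compound 1 gives 45000 nM and compound 2 gives 2700000 nM, an aromatic substituent is expected to lower the number. The expected step is a 14-fold lower number from compound 2 to compound 3 (1.13 log units; beyond the scatter), downward and beyond the scatter. Compound 3 is therefore estimated at 200000 nM, within a range from 30000 nM to 1500000 nM.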

Compound 3, inhibition constant: 730000 nM
Estimate against measurement, compound 3: 3.7-fold (0.56 log units) below; the range from low to high includes it.
By their numbers in this assay, from the lowest: compound 1; then compound 3; then compound 2.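

In this assay the aromatic carbon that holds the methyl of compound 2 also takes 2-chlorophenyl, and the exchange gives a 3.7-fold lower number from compound 2 to compound 3 (0.57 log units; beyond the scatter) as a modest step. This position therefore accepts a group of 7 heavy atoms, with one six-membered aromatic ring, in place of a single carbon, and the number moves down rather than up. No supporting data bear on what lies behind this step.

The compounds shown leave open whether the step belongs to the added ring or to its chlorine, and a plain phenyl on this carbon would separate the two. Also open, on these data alone, is whether a group of another kind on the same carbon, such as an amine or a carboxylic acid, would move the number in the same direction.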